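One methyl less: from compound 2 to compound 3

The source may hold more compounds than are shown below. What is called first, only, known or untested is meant among the compounds shown, and "the series" means these compounds.

In an assay on HEK293 cells for inhibition of transient receptor potential cation channel subfamily M member 8 (Homo sapiens), read by FLIPR, with stated times of 5 min and 3 min (on this read-out higher numbers stand for weaker inhibition and lower numbers for stronger inhibition), compound 1 `CCOC(=O)c1ccc(-c2cccc(F)c2)cc1O` reports only a limit of > 100000 nM. Going by the values given here, compound 2 `CCn1nnc(-c2sc(-c3cccc(OC)c3)nc2O)n1` is the only compound with an actual number in this assay, where compound 2 gives 245 nM. Compound 3 `CCn1nnc(-c2sc(-c3cccc(O)c3)nc2O)n1` differs from compound 2 by hydrogen in place of methyl on an oxygen on an aromatic ring. Among the compounds with values here, no measured pair shows this change; the step is expected to be modest, within the scatter or a slight loss, as a 1.6-fold higher number from compound 2 to compound 3 (0.21 log units; within the scatter). Compound 3 is therefore estimated at 400 nM, between 100 nM and 2000 nM.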

Compound 3, half-maximal inhibitory concentration: 239 nM
Beside the measured number, compound 3's estimate is 1.7-fold (0.22 log units) above it; the measured number falls inside the stated range.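

Until now no step could be read at this position, but in this assay this pair gives a 1.0-fold lower number from compound 2 to compound 3 (0.01 log units; within the scatter) and so shows that the methyl on this oxygen on an aromatic ring can give way to hydrogen without a difference beyond the scatter. For this pair, hydroxy serves as well as methoxy. Nothing shown gives a cause for this result.

As far as these compounds go, whether an amine in place of the hydroxy, or a longer chain such as ethyl on this oxygen, would serve as well stays open. This single pair speaks only for methyl and hydrogen.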